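The source may hold more compounds than are shown below. What is called first, only, known or untested is meant among the compounds shown, and "the series" means these compounds.

Two compounds of this series have been examined in a functional assay on A549 cells (Homo sapiens) for cytotoxicity, with a stated time of 48 h; on this read-out higher numbers stand for weaker inhibition and lower numbers for stronger inhibition. Compound 1, `Cc1c(/C=C/[S+](C)[O-])oc2ccccc2c1=O`, gives 1500 nM in this assay. Compound 2, `C[S+]([O-])/C=C/c1cc(=O)c2cc(Cl)ccc2o1`, gives 1700 nM in this assay; its number is the higher of the two, but the two values sit within the usual scatter of one another, so the data show no real separation between them.

The next compound, compound 3, is `C[S+]([O-])/C=C/c1cc(=O)c2cc(Br)ccc2o1`. It keeps the whole core of compound 2 and changes only one substituent: bromo in place of chloro on an aromatic carbon. Swapping one halogen for another of this kind is a small change, and with only two measured compounds there is no step of this sort to draw on. The expectation is therefore for no change beyond the scatter, with the step of a 1.1-fold lower number from compound 2 to compound 3 (0.05 log units; within the scatter) expected to stay small. Compound 3 is estimated to give 1500 nM in this assay, in a range from 700 nM to 3500 nM.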

Compound 3, half-maximal inhibitory concentration: 1100 nM
For compound 3 the middle estimate is 1.4-fold (0.13 log units) above the measured one; measured number inside the range.
By their numbers in this assay, from the lowest: compounds 3, 1 and 2 (each within the scatter of the next).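

Within the data shown here, compound 3 gives the first direct reading of a single change at this aromatic carbon: in this assay, bromo in place of chloro gives a 1.5-fold lower number from compound 2 to compound 3 (0.19 log units; within the scatter) and stays within the usual scatter. On this read-out, therefore, the two halogens cannot be told apart at this position on the shared core, although one step with one pair of halogens says nothing about other substituents there. The information at hand offers no measured basis for explaining this result.

Still open, on these data alone, is whether this carbon responds to a group quite unlike a halogen, such as an amine, a methoxy group or a carboxylic acid. As far as these compounds go, it also remains unknown how the values would move if the side chain on the shared core were replaced by a longer chain.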